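This account rests on a few compounds, and the source may have more. Where it says the series, first, only, none or still open, it means among the compounds named here.

Three compounds have been measured in a functional assay on A549 cells (Homo sapiens) for antiproliferative activity, read by XTT assay, with a stated time of 72 h; a higher number here means a weaker inhibitor, a lower number a stronger inhibitor:
compound 1 `COc1ccc(-c2cc3ccccc3nc2/C=C/C(=O)c2ccc(F)cc2)cc1`, 8320 nM;
compound 2 `COc1ccc(C(=O)/C=C/c2nc3ccccc3cc2-c2ccc(OC)cc2)cc1`, 8500 nM;
compound 3 `COc1ccc(-c2cc3ccccc3nc2/C=C/C(=O)c2ccc(OC)c(OC)c2)cc1`, 8860 nM.

Compound 3 carries the highest of the three numbers, but its separations from the others, a 1.1-fold higher number from compound 1 to compound 3 (0.03 log units; within the scatter) and a 1.0-fold higher number from compound 2 to compound 3 (0.02 log units; within the scatter), both lie within the scatter, so the three stand level. Compound 4 `COc1ccc(-c2cc3ccccc3nc2/C=C/C(=O)c2ccco2)cc1` differs from compound 3 by furan-2-yl in place of 3,4-dimethoxyphenyl on a carbonyl carbon. Among the compounds with values here, the steps that bear on this place are a 1.1-fold higher number from compound 1 to compound 3 (0.03 log units; within the scatter) and a 1.0-fold higher number from compound 2 to compound 3 (0.02 log units; within the scatter), both within the scatter; no measured compound carries a furan-2-yl, so the change itself is uncharted. Given those two flat steps, the expected move in this assay is a 1.0-fold higher number from compound 3 to compound 4 (0.01 log units; within the scatter), nothing beyond the scatter, with wide uncertainty. The estimate for compound 4 is 9000 nM, ranging from 3000 nM to 27000 nM.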

Compound 4, half-maximal inhibitory concentration: 6130 nM
Compound 4: the middle estimate sits 1.5-fold (0.17 log units) above what was measured, and the stated range covers the measured number.
By their numbers in this assay, from the lowest: compounds 4, 1, 2 and 3 (each within the scatter of the next).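

In this assay, the carbonyl carbon now proves to accept a five-membered aromatic ring as well as the six-membered ones: the steps (a 1.4-fold lower number from compound 3 to compound 4 (0.16 log units; within the scatter)) and (a 1.4-fold lower number from compound 2 to compound 4 (0.14 log units; within the scatter)) and (a 1.4-fold lower number from compound 1 to compound 4 (0.13 log units; within the scatter)) all lie within the scatter. Furan-2-yl, with fewer heavy atoms than 3,4-dimethoxyphenyl, thus stands level with all three earlier groups. Nothing available accounts for this flatness.

Going by these compounds, whether any group on this carbonyl carbon can move the number beyond the scatter remains open. A piperidine ring or a carboxylic acid there would test this.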